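A few compounds are considered here, and "the series" means these few. Any claim that something is new, unique, unknown or untested is made for them only; others in the source may bear on it.

Two compounds of this series carry measurements. Compound 1 `CC1(C)N(O)C(c2ccc(O)cc2)=[N+]([O-])C1(C)C` gives, in a functional assay on PC-12 cells (Rattus norvegicus) for inhibition, read by MTT assay (on this read-out higher numbers stand for an effect only at larger amounts of compound and lower numbers for an effect already at smaller amounts), 40000 nM. Compound 2 `CC1(C)N(O)C(c2ccc(OCC(=O)N[C@@H](CCCCN)C(=O)O)cc2)=[N+]([O-])C1(C)C` gives in this assay 90600 nM, the higher of the two numbers; compound 1 sits below it by a gap that lies beyond the usual scatter of repeated measurements.

Compound 3 `CC1(C)N(O)C(c2ccc(OCC(=O)N[C@@H](CCCNC(=N)N)C(=O)O)cc2)=[N+]([O-])C1(C)C` has not yet been measured. It differs from compound 2 in one place: a group of 4 heavy atoms (1 carbon, 3 nitrogen; no ring) in place of a group of 2 heavy atoms (1 carbon, 1 nitrogen; no ring), on a saturated chain carbon, four bonds along the chain from an amide-type nitrogen and a carbonyl carbon. The group that leaves is an aminomethyl; the group that enters is larger by two heavy atoms and carries two more hydrogen-bond donors, while the remainder of the molecule, including the shared core and the chain that links it to the side group, is unchanged.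

Going by the values given here, no measured pair in this set shows what such an exchange does, so the expectation rests on compound 2 alone. Compound 3 is expected to land close to compound 2, with a step of a 1.1-fold lower number from compound 2 to compound 3 (0.03 log units; within the scatter) that need not go beyond the scatter in either direction. The estimate for compound 3 in this assay is 85000 nM, within a range from 30000 nM to 240000 nM.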

Compound 3, half-maximal effective concentration: 92900 nM
For compound 3 the middle estimate is 1.1-fold (0.04 log units) below the measured one; the measured number falls inside the stated range.
By their numbers in this assay, from the lowest: compound 1; then compounds 2 and 3 (each within the scatter of the next).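

Going by these compounds alone, on the saturated chain carbon four bonds along the chain from an amide-type nitrogen and a carbonyl carbon, the earlier compounds showed nothing about exchanging the group, and the first such exchange gives a 1.0-fold higher number from compound 2 to compound 3 (0.01 log units; within the scatter) in this assay. Replacing the aminomethyl with the group of 4 heavy atoms, with its added hydrogen-bond donors, therefore leaves the read-out within the scatter for this pair. No measurement offered here explains why the number stays level.

The compounds shown leave open whether a carboxylic acid, a hydroxyl or a plain methyl in place of the aminomethyl on this carbon would also stay level with compound 2 in this assay. They also leave open what a longer chain carrying the same amine would do.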